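Compound 3 to compound 4: a longer 1-aminobutyl chain

This account rests on a few compounds, and the source may have more. Where it says the series, first, only, none or still open, it means among the compounds named here.

Compound 1 `C[C@H](N)C(=O)N[C@@H]1CN(c2nc3c(cc2F)c(=O)c(C(=O)O)cn3C2CC2)[C@H]1C`: > 500 ug/mL
Compound 2 `C[C@H]1[C@H](N)CN1c1nc2c(cc1F)c(=O)c(C(=O)O)cn2C1CC1`: 16.5 ug/mL
Compound 3 `C[C@H](N)C(=O)N[C@@H]1CN(c2cc3c(cc2F)c(=O)c(C(=O)O)cn3-c2ccc(F)cc2F)[C@H]1C`: > 500 ug/mL

In a physicochemical assay for solubility, at pH 7.4 (a lower number here means a less soluble compound, a higher number a more soluble compound), compound 3 gives > 500 ug/mL, which is a limit and not a number. The same holds for compound 1, so the series has (the limit of > 500 ug/mL in this assay, at which 2 of the 3 values shown sit).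

Compound 4 `CCC[C@H](N)C(=O)N[C@@H]1CN(c2cc3c(cc2F)c(=O)c(C(=O)O)cn3-c2ccc(F)cc2F)[C@H]1C` carries ethyl in place of hydrogen on a saturated chain carbon, two bonds along the chain from an amine nitrogen and a carbonyl carbon. The same difference reads 1-aminoethyl to 1-aminobutyl.

Going by the values given here, one measured step bears on this, and only indirectly. It is an at least 30-fold lower number from compound 1 to compound 2 (1.48 log units; beyond the scatter), a large change beyond the scatter, and it removes the whole (1-aminoethyl)carbonyl on a core other than that of compound 3. Among the compounds with values here, compound 4 keeps that group in its (1-aminobutyl)carbonyl form, and no measured step covers a change of chain length. A step far smaller than that one is therefore expected, towards a lower number in this assay. The expected change is an at least 1.4-fold lower number from compound 3 to compound 4 (0.15 log units; that floor lies within the scatter). Compound 4 is estimated at 350 ug/mL, with an expected range of 100 ug/mL to 700 ug/mL.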

Compound 4, solubility: > 500 ug/mL
Compound 4: only a limit was reported; the forecaster's own chance of this, stated with the estimate: 40%; at least 1.4-fold (0.15 log units) between middle value and limit.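

No step from compound 3 to compound 4 can be read, because each of the two results is a limit and not a number: the limit of > 500 ug/mL in this assay, at which 3 of the 4 values shown sit.

The compounds shown leave open whether, and how far, going from 1-aminoethyl to 1-aminobutyl moves the number in this assay.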